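Swapping the benzyl aryl group on a triazole thioether

The compounds below may be only part of what the source reports. "The series", "measured", "known", "first", "only" and "open" are said of these compounds alone.

Measured compounds:
compound 1, `O=[N+]([O-])c1ccc(CSc2nnc(-c3ccc4c(c3)OCCO4)n2-c2ccccc2)cc1`: 13800 nM
compound 2, `COc1cccc(CSc2nnc(-c3ccc4c(c3)OCCO4)n2-c2ccccc2)c1`: 10100 nM
compound 3, `Cc1ccccc1CSc1nnc(-c2ccc3c(c2)OCCO3)n1-c1ccccc1`: 12700 nM

All three numbers come from a functional assay on SW 1116 cells (Homo sapiens) for antiproliferative activity, read by MTT assay, with a stated time of 24 h; on this read-out lower numbers stand for stronger inhibition and higher numbers for weaker inhibition. Compound 1 gives the highest of the three, yet the steps of a 1.4-fold lower number from compound 1 to compound 2 (0.14 log units; within the scatter) and a 1.1-fold lower number from compound 1 to compound 3 (0.04 log units; within the scatter) both fall within the scatter, and so does a 1.3-fold higher number from compound 2 to compound 3 (0.10 log units; within the scatter). The three compounds therefore sit on one level, and nothing among them separates a 4-nitrophenyl, a 3-methoxyphenyl and a 2-methylphenyl group on the saturated chain carbon bound to the sulfur.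

Compound 4, `Brc1ccccc1CSc1nnc(-c2ccc3c(c2)OCCO3)n1-c1ccccc1`, has not yet been measured. Its difference from compound 1 is 2-bromophenyl in place of 4-nitrophenyl on a saturated chain carbon bound to a sulfur. The three measured steps all exchange the aryl group at this same place, and none of them moved the number beyond the scatter. Among the measured compounds shown here, they are the only guide available, and on that basis no step beyond the scatter is expected in this assay in either direction.

Compound 4 is therefore estimated to give about 12000 nM, with a range from 6000 nM to 24000 nM. The step this estimate implies, a 1.2-fold lower number from compound 1 to compound 4 (0.06 log units; within the scatter), is expected to remain within the scatter.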

Compound 4, half-maximal inhibitory concentration: 7350 nM
Beside the measured number, compound 4's estimate is 1.6-fold (0.21 log units) above it; measured number inside the range.
By their numbers in this assay, from the lowest: compounds 4, 2, 3 and 1 (each within the scatter of the next).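

In this assay, the 2-bromophenyl group of compound 4 joins the same level as the three aryl groups before it, which extends the flat picture to a fourth group and to the first halogen at this place: a 1.9-fold lower number from compound 1 to compound 4 (0.27 log units; within the scatter), and a 1.4-fold lower number from compound 2 to compound 4 (0.14 log units; within the scatter). Among the compounds shown here, the closest comparison is a 1.7-fold lower number from compound 3 to compound 4 (0.24 log units; within the scatter), where the only exchange is bromo in place of methyl on an aromatic carbon, so this single swap on the ring also leaves the number where it was. The step from compound 1 further shows that a group carrying hydrogen-bond acceptors can give way to one carrying none without a step beyond the scatter, and no other kind of measurement is at hand to bear on this result.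

Going by these compounds, all four compounds keep a substituted phenyl ring on the saturated chain carbon bound to the sulfur, so it remains open whether an amine or a carboxylic acid on that ring, or a longer chain in place of the benzyl carbon, would move the number beyond the scatter. The shared core is the same throughout, so these numbers also say nothing about changes made elsewhere in it.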